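The source may report more compounds than this note shows. Statements on the series, on what has been measured and on what is new or still open speak of the compounds shown alone.

Compound 1 `Cc1cccc(C(=O)NCN2CCC(c3ccccn3)CC2)c1` was examined in a functional assay on HEK293 cells for agonist activity at D(4) dopamine receptor (Homo sapiens), read by FLIPR (a higher number here means a larger maximal response, a lower number a smaller maximal response), where compound 1 gives 67%. Two other compounds were measured in the same way: compound 2 `O=C(CN1CCC(c2cccc[n+]2[O-])CC1)Nc1ccc(F)cc1F`, which in this assay gives 74%, and compound 3 `Oc1ccc(N2CCN(Cc3nc4ccccc4[nH]3)CC2)nc1`, which in this assay gives 70%. Compound 1 carries the lowest of the three numbers, yet all three values lie within the usual scatter of one another, so none of them can be told apart from the rest on these data.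

Compound 4 `Cc1cccc(C(=O)NCN2CCC(c3nccs3)CC2)c1` has not yet been measured in this assay. It differs from compound 1 in one place: 1,3-thiazol-2-yl in place of pyridin-2-yl on a saturated ring carbon. Among the compounds with values here, no measured pair shows what this exchange does to the maximal response, so nothing about its direction can be read from the data. The expected size of the step of a number 2 percentage points lower from compound 1 to compound 4 (within the scatter) is therefore none beyond the scatter. Compound 4 is estimated to reach 65% in this assay, with a range of 45% to 85%.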

Compound 4, largest response reached (reported as efficacy), in percent of the reference or control that the assay uses: 71%
Compound 4: the middle estimate sits 6 percentage points below what was measured, and the stated range covers the measured number.
By their numbers in this assay, from the lowest: compounds 1, 3, 4 and 2 (each within the scatter of the next).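

In this assay, within the data shown here, the exchange of pyridin-2-yl for 1,3-thiazol-2-yl on a saturated ring carbon gives a number 4 percentage points higher from compound 1 to compound 4 (within the scatter), the first direct comparison at this position. A five-membered aromatic ring with 2 hetero atoms, one of them sulfur, can therefore stand in place of the six-membered aromatic ring without a change in maximal response that can be told from the scatter. No independent measurement is available to connect this result to any underlying cause.

This single pair leaves open whether the position would respond to a plain phenyl, a pyrimidin-2-yl or a non-aromatic group such as a primary amine or a carboxylic acid. It also leaves open whether the same exchange would give a similar result on a different core.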